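The compounds below may be only part of what the source reports. "The series", "measured", "known", "first", "only" and "open" are said of these compounds alone.

In a functional assay on MDA-MB-231 cells (Homo sapiens) for cytotoxicity, read by MTT assay (a higher number here means a weaker inhibitor, a lower number a stronger inhibitor), compound 1 `COc1ccc(-n2cc(-c3ccc(OC)c(OC)c3)nn2)cc1O` reaches only a limit of the assay, > 1000 nM. Compound 3 `COc1ccc(-c2cn(-c3ccc(OC)c(O)c3)nn2)cc1` likewise reaches only a limit of the assay, > 100 nM. The change between them is hydrogen in place of methoxy on an aromatic carbon. The step that this change makes, a step that the two limits leave unreadable from compound 1 to compound 3, has no readable size, as shown by the limit of > 1000 nM in this assay, at which 1 of the 3 values shown sits, and (the limit of > 100 nM in this assay, at which 1 of the 3 values shown sits).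

Compound 2 `COc1cc(-c2cn(-c3cc(OC)c(OC)c(OC)c3)nn2)cc(OC)c1OC` also reaches only a limit of the assay, > 10000 nM, as recorded in the limit of > 10000 nM in this assay, at which 1 of the 3 values shown sits. The difference between the cores of compound 1 and compound 2 is not broken down here.

Compound 4 `COc1cc(OC)cc(-c2cn(-c3cc(OC)c(OC)c(OC)c3)nn2)c1` is not yet measured in this assay. It differs from compound 2 by hydrogen in place of methoxy on an aromatic carbon. Within the data shown here, this is the same kind of change as the one from compound 1 to compound 3, but not the same: there the leaving methoxy sat ortho to a methoxy group and meta to a large group, whereas here it sits ortho to two methoxy groups and para to a large group.

Among the measured compounds shown here, since every measured value sits at a limit, no measured step gives a size to lean on, and the expectation for compound 4 rests on the limit reached by compound 2 in this assay. For compound 4 the expected step is a step that the limit leaves unreadable from compound 2 to compound 4. Compound 4 is therefore estimated at 20000 nM, expected to fall between 5000 nM and 80000 nM, most likely again as a limit rather than a number.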

Compound 4, half-maximal inhibitory concentration: > 10000 nM
Compound 4: a limit, no number; the forecaster's own chance of this, stated with the estimate: 70%; the middle value is on the limit's open side.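

Compound 2 and compound 4 both stop at a limit of this assay rather than giving a number, so no size can be read for the change between them: the limit of > 10000 nM in this assay, at which 2 of the 4 values shown sit.

The compounds shown leave open how strong any of them truly is in this assay, and whether hydrogen in place of methoxy on an aromatic carbon changes the result at all.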